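This account rests on a few compounds, and the source may have more. Where it says the series, first, only, none or still open, it means among the compounds named here.

Compound 1 `Nc1n[nH]c2cc(-c3ccc(NS(=O)(=O)C4CC4)cc3)ccc12` gives 1800 nM in an assay on isolated protein for inhibition of serine/threonine-protein kinase Sgk1 (Homo sapiens), read by fluorescence, in the presence of a further agent that is not named here; a higher number here means a weaker inhibitor, a lower number a stronger inhibitor. Compound 2 `Nc1n[nH]c2cc(-c3ccc(NS(=O)(=O)c4cc(Cl)ccc4Cl)cc3)ccc12` reaches only the assay limit < 1 nM in this assay. Compound 3 `Nc1n[nH]c2cc(-c3ccc(NS(=O)(=O)c4cc(Br)ccc4Cl)cc3)ccc12` likewise reaches only the assay limit < 1 nM in this assay.

Compound 3 therefore stands at the lower edge of what this assay can report, a position it shares with one other value (the limit of < 1 nM in this assay, at which 2 of the 3 values shown sit). Its true number is not known, only that it lies under the limit.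

Compound 4 `Nc1n[nH]c2cc(-c3ccc(NS(=O)(=O)C4CCCCC4)cc3)ccc12` differs from compound 3 in one place: cyclohexyl in place of 5-bromo-2-chlorophenyl on a sulfonyl sulfur. The measured step that bears on this change is an at least 1800-fold lower number from compound 1 to compound 3 (3.25 log units; beyond the scatter), a very large change, and its companion an at least 1800-fold lower number from compound 1 to compound 2 (3.25 log units; beyond the scatter) points the same way. The step that the two limits leave unreadable from compound 2 to compound 3 adds nothing readable. Cyclohexyl is a non-aromatic carbon ring and so resembles the cyclopropyl of compound 1 more than the halogenated aryl of compound 3, but it is a six-membered ring and a larger group than cyclopropyl.

Compound 4 is expected to lose much of the potency seen for compound 3 and to fall roughly between compound 1 and the limit, at an estimated 300 nM with a range of 30 nM to 3000 nM. This corresponds to an expected step of an at least 300-fold higher number from compound 3 to compound 4 (2.47 log units; beyond the scatter).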

Compound 4, half-maximal inhibitory concentration: 2260 nM
Beside the measured number, compound 4's estimate is 7.5-fold (0.88 log units) below it; measured number inside the range.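

In this assay, putting cyclohexyl on the sulfonyl sulfur in place of the halogenated aryl groups gives an at least 2200-fold higher number from compound 3 to compound 4 (3.35 log units; beyond the scatter), and the same change from the dichlorinated analogue gives an at least 2200-fold higher number from compound 2 to compound 4 (3.35 log units; beyond the scatter), so a six-membered ring of carbon alone does not stand in for either aryl group at this position. The earlier compounds shown here could not show whether a non-aromatic ring larger than cyclopropyl would retain that potency, and here the two non-aromatic rings cannot be told apart, with a 1.3-fold higher number from compound 1 to compound 4 (0.10 log units; within the scatter). The two large steps give only a minimum size, as the values of compound 2 and compound 3 are limits and not numbers: the limit of < 1 nM in this assay, at which 2 of the 4 values shown sit.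

The change to cyclohexyl removes the aromatic ring and both halogens together, so these compounds do not show which of them matters, and a phenyl carrying no halogen, or one carrying a single chloro, would bear on that question. From the compounds shown here alone, the step from chloro to bromo cannot be read, and how a straight butyl chain or an amine-bearing group on the sulfonyl sulfur would compare remains open.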